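Trimming the methoxy from the benzyl arm

The source may hold more compounds than are shown below. What is called first, only, known or untested is meant among the compounds shown, and "the series" means these compounds.

Measured compounds in a functional assay on HeLa cells (Homo sapiens) for inhibition, read by cell counting, with a stated time of 4 days; a lower number here means a stronger inhibitor, a higher number a weaker inhibitor:
Compound 1 `C=C(Br)C(=O)Nc1cccc(-c2cn3nc(-c4ccc(F)cc4)sc3n2)c1` gives 870 nM.
Compound 2 `C=C(Br)C(=O)Nc1cccc(-c2cn3nc(Cc4cccc(OC)c4)sc3n2)c1` gives 2500 nM.

Compound 2 has the highest number of the two, and the only step shown, a 2.9-fold higher number from compound 1 to compound 2 (0.46 log units; beyond the scatter), is modest. Compound 3 `C=C(Br)C(=O)Nc1cccc(-c2cn3nc(Cc4ccccc4)sc3n2)c1` differs from compound 2 by hydrogen in place of methoxy on an aromatic carbon. For the measured compounds named here, no measured step removes a methoxy, so the swap of aryl for benzyl between compound 1 and compound 2 gives only indirect guidance. The expected step of no change at the digits printed from compound 2 to compound 3 (within the scatter) is therefore none beyond the scatter. Compound 3 is estimated at 2500 nM, within a range from 1000 nM to 6000 nM.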

Compound 3, half-maximal inhibitory concentration: 4500 nM
Beside the measured number, compound 3's estimate is 1.8-fold (0.26 log units) below it, and the stated range covers the measured number.
By their numbers in this assay, from the lowest: compound 1; then compounds 2 and 3 (each within the scatter of the next).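

In this assay the methoxy can be taken off the benzyl arm with only a 1.8-fold higher number from compound 2 to compound 3 (0.26 log units; within the scatter) as the result, so at this place on the ring the group's loss does not stand out from the scatter. With no methoxy on the arm, putting benzyl in place of 4-fluorophenyl gives a 5.2-fold higher number from compound 1 to compound 3 (0.71 log units; beyond the scatter) as a step beyond the scatter. Nothing available explains either step.

Still open, from the compounds shown here alone, is whether an amine or a chlorine in place of the methoxy would move the number. Going by these compounds, a longer chain in place of the benzyl arm is equally open.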